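Benzyl on the amide nitrogen across two cores

The source may hold more compounds than are shown below. What is called first, only, known or untested is meant among the compounds shown, and "the series" means these compounds.

Working notes on a small set built around a shared nitro-methylsulfonyl benzamide head, tested in an assay on isolated protein for inhibition of thyroid hormone receptor beta (Homo sapiens), read by fluorescence polarization; a lower number here means a stronger inhibitor, a higher number a weaker inhibitor. Compound 3 `CN(Cc1ccccc1)C(=O)CNC(=O)c1ccc(S(C)(=O)=O)c([N+](=O)[O-])c1` gives 39000 nM in this assay. Compound 2 `CS(=O)(=O)c1ccc(C(=O)NCC(=O)N(Cc2ccccc2)Cc2ccccc2)cc1[N+](=O)[O-]` gives 3600 nM in this assay. The change between them is phenyl in place of hydrogen on a saturated chain carbon bound to an amide-type nitrogen, and it carries an 11-fold lower number from compound 3 to compound 2 (1.03 log units; beyond the scatter) step.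

Compound 1 `CN(Cc1ccccc1)C(=O)C1CCN(C(=O)c2ccc(S(C)(=O)=O)c([N+](=O)[O-])c2)CC1` is the piperidine-linked counterpart of compound 3, and the difference between the two cores is not broken down here. In this assay compound 1 reports only a limit, > 60000 nM, as noted in the limit of > 60000 nM in this assay, at which 1 of the 3 values shown sits.

Compound 4 `CS(=O)(=O)c1ccc(C(=O)N2CCC(C(=O)N(Cc3ccccc3)Cc3ccccc3)CC2)cc1[N+](=O)[O-]` carries the same change relative to compound 1, namely (phenyl in place of hydrogen on a saturated chain carbon bound to an amide-type nitrogen), at the same place as in the measured pair. The step from compound 1 to compound 4 is expected to be an at least 4.0-fold lower number from compound 1 to compound 4 (0.60 log units; beyond the scatter), set beside the measured 11-fold lower number from compound 3 to compound 2 (1.03 log units; beyond the scatter) and resting on that single pair. Because compound 1 shows only the limit > 60000 nM, the starting point is uncertain. Compound 4 is estimated at 15000 nM in this assay, between 4000 nM and 60000 nM.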

Compound 4, half-maximal inhibitory concentration: > 60000 nM
Compound 4 ended at the assay's limit; the forecaster's own chance of this, stated with the estimate: 30%; middle value at least 4.0-fold (0.60 log units) away from the limit.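

In this assay compound 4 gives > 60000 nM, which is a limit of the assay and not a number. Within the data shown here, compound 1 is also held at a limit, so no step between compound 1 and compound 4 can be read: the limit of > 60000 nM in this assay, at which 2 of the 4 values shown sit. The compounds shown leave open whether phenyl in place of hydrogen changes the number at all on the core of compound 1.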